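Chloro added to the shared core: an expected small step

This account rests on a few compounds, and the source may have more. Where it says the series, first, only, none or still open, it means among the compounds named here.

Measured compounds:
compound 1, `ClCc1cccc(Cn2cnc3ncnc(Cl)c32)c1` — 1770 nM
compound 2, `ClCc1cccc(Cn2cnc3c(Cl)nc(Cl)nc32)c1` — 1620 nM

Two compounds share the same core and have been run in a functional assay on HCT-116 cells (Homo sapiens) for cytotoxicity, read by sulforhodamine B assay, with a stated time of 48 h; on this read-out higher numbers stand for weaker inhibition of growth and lower numbers for stronger inhibition of growth. In this assay compound 1 gives 1770 nM, and compound 2 gives 1620 nM. Going by the values given here, the two numbers lie within the scatter of each other, so neither compound can be set above the other on what has been measured; compound 1 simply shows the one number and compound 2 the other, with no step to read between them.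

The compound still to be measured is compound 3, `ClCc1cccc(Cn2cnc3nc(Cl)nc(Cl)c32)c1`. It differs from compound 1 in one place: chloro in place of hydrogen on an aromatic carbon. Among the compounds with values here, no pair of measured compounds shows this exact change, so nothing measured fixes its size. The closest hint is that compound 2, which also carries two chloro groups on the core, gives 1620 nM, close to compound 1. On that basis the step from compound 1 to compound 3 is expected to be small in this assay, a 1.2-fold lower number from compound 1 to compound 3 (0.07 log units; within the scatter), with no direction clear beyond the scatter. Compound 3 is therefore estimated at 1500 nM, with a range from 600 nM to 3800 nM.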

Compound 3, concentration for 50% growth inhibition: 750 nM
For compound 3 the middle estimate is 2.0-fold (0.30 log units) above the measured one, within the range that was stated.
By their numbers in this assay, from the lowest: compound 3; then compounds 2 and 1 (each within the scatter of the next).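

Going by these compounds alone, the change of hydrogen to chloro on an aromatic carbon, between two ring nitrogen atoms, gives the first step that can be read on the shared core: in this assay it amounts to a 2.4-fold lower number from compound 1 to compound 3 (0.37 log units; beyond the scatter). Within the data shown here, compound 1 and compound 2 had offered no step, so compound 3 is the first sign that this single change can register above the scatter, and its direction is towards stronger inhibition of growth. No measurement shown here accounts for the step, so it stands as an observation on one pair of compounds, with no explanation attached.

The compounds shown carry only hydrogen or chloro at this position, so it remains open whether an amine, a methoxy group or a fluoro group there would match this step, exceed it or lose it. From the compounds shown here alone, it also remains open whether the same change would give a similar step if the chloromethyl group on the benzene ring were replaced, for instance by a methyl group or a carboxylic acid.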